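The source may report more compounds than this note shows. Statements on the series, on what has been measured and on what is new or still open speak of the compounds shown alone.

Measured so far:
- Compound 1 `COc1ccc(CN(C(=O)CSc2nc3ccccc3s2)c2cc(OC)c(OC)c(OC)c2)cc1N=[N+]=[N-]`: 187 nM
- Compound 2 `COc1ccc(CN(C(=O)CSc2nc3ccccc3s2)c2cc(OC)c(OC)c(OC)c2)cc1F`: 416 nM

In a functional assay on MGC-803 cells (Homo sapiens) for antiproliferative activity, read by MTT assay, with a stated time of 48 h (on this read-out lower numbers stand for stronger inhibition and higher numbers for weaker inhibition), compound 2 gives 416 nM, the higher of the two numbers. Compound 3 `COc1ccc(CN(C(=O)CSc2nc3ccccc3s2)c2cc(OC)c(OC)c(OC)c2)cc1Br` carries bromo in place of fluoro on an aromatic carbon, ortho to a methoxy group: bromo in place of fluoro on an aromatic carbon. Among the compounds with values here, one measured step bears on this carbon, the modest 2.2-fold higher number from compound 1 to compound 2 (0.35 log units; beyond the scatter), where fluoro replaced azido. Within the data shown here, no bromo compound has been measured, so the evidence is thin, but a modest move back toward a lower number is expected in this assay. The expected change is a 1.5-fold lower number from compound 2 to compound 3 (0.17 log units; within the scatter). Compound 3 is estimated at 280 nM, with a range of 110 nM to 650 nM.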

Compound 3, half-maximal inhibitory concentration: 852 nM
Compound 3: middle estimate off by 3.0-fold (0.48 log units), on the low side; the whole stated range lies below it.
By their numbers in this assay, from the lowest: compound 1; then compound 2; then compound 3.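

In this assay, the aromatic carbon ortho to a methoxy group responds to the choice of halogen as well: bromo in place of fluoro gives a 2.0-fold higher number from compound 2 to compound 3 (0.31 log units; beyond the scatter), so the change moves away from the azido compound rather than back toward it. Bromo in place of azido gives a 4.6-fold higher number from compound 1 to compound 3 (0.66 log units; beyond the scatter), which places both halogens on the higher side of azido. Nothing available here accounts for these differences. As far as these compounds go, whether chloro would fall between fluoro and bromo stays open. So does how an amine or a methyl group on this carbon would read.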